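The source may report more compounds than this note shows. Statements on the series, on what has been measured and on what is new or still open speak of the compounds shown alone.

Measured so far in a functional assay on KB cells (Homo sapiens) for inhibition, read by MTT assay, with a stated time of 24 h, tested at 1 ug/mL; on this read-out lower numbers stand for less inhibition of growth and higher numbers for more inhibition of growth at the one concentration tested:
- compound 1 `O=C(CCCCC(S)CCS)Nc1ccc(Cl)cc1`: 13.4%
- compound 2 `O=C(CCCCC(S)CCS)Nc1ccc(F)cc1`: 8.84%
- compound 3 `O=C(CCCCC(S)CCS)Nc1ccc([N+](=O)[O-])c(C(F)(F)F)c1`: 10.2%

All of these values are low on this read-out. In this assay, compound 3 gives 10.2%, which lies within the scatter of both compound 1 and compound 2, so the three compounds cannot be ranked.

The next compound is compound 4 `O=C(CCCCC(S)CCS)Nc1ccc([N+](=O)[O-])cc1`, not yet measured. The change is hydrogen in place of trifluoromethyl on an aromatic carbon. The nitro group and the rest of the structure stay the same.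

Within the data shown here, only one measured step involves a change of aromatic substituent, a number 4.6 percentage points lower from compound 1 to compound 2 (within the scatter). It lies within the scatter, but it exchanges fluoro for chloro, so it bears on the present change only indirectly. Among the measured compounds shown here, no measured step removes a trifluoromethyl group, and the data therefore leave this particular change untested. With nothing beyond the scatter seen so far, no direction can be assigned. The step of a number 0.2 percentage points lower from compound 3 to compound 4 (within the scatter) is expected to stay within the scatter.

For compound 4, the estimated value is 10%, with an expected range of 3% to 18%.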

Compound 4, percent growth inhibition at one concentration: 0.93%
Estimate against measurement, compound 4: 9.1 percentage points above; the whole stated range lies above it.
By their numbers in this assay, from the lowest: compounds 4, 2, 3 and 1 (each within the scatter of the next, the first and the last beyond it).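

In this assay, hydrogen in place of trifluoromethyl on the aromatic carbon ortho to the nitro group gives a number 9.3 percentage points lower from compound 3 to compound 4 (within the scatter) for the first tested removal of this group, so with the nitro group and the rest of the structure held constant, this change cannot be told from the usual scatter. Nitro in place of fluoro gives a number 7.9 percentage points lower from compound 2 to compound 4 (within the scatter) and likewise remains unresolved, whereas nitro in place of chloro gives a number 12.5 percentage points lower from compound 1 to compound 4 (beyond the scatter) as the first step in the series to pass beyond the scatter, though it remains modest and compound 4 is separated only from compound 1. The available data offer no measured basis for assigning a cause to any of these steps.

The compounds shown leave open whether an amine or a carboxylic acid in place of the nitro group would give a step beyond the scatter from compound 4 in this assay at the one concentration tested. They also leave open whether a longer chain on the amide carbonyl would shift these low values, with the substituted aromatic ring kept as in compound 4.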